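Phenyl for methyl on the pyridone-type core: ABHD6 series

The source may hold more compounds than are shown below. What is called first, only, known or untested is meant among the compounds shown, and "the series" means these compounds.

Measured so far:
Compound 1, `O=C(NC1CCCCCC1)c1c(-c2ccccc2)c(Br)cn(Cc2ccc(F)cc2)c1=O`: 3000 nM
Compound 2, `O=C(NC1CCCCCC1)c1c(-c2ccccc2)ccn(Cc2ccc(F)cc2)c1=O`: > 10000 nM
Compound 3, `Cc1c(-c2ccccc2)cn(Cc2ccc(F)cc2)c(=O)c1C(=O)NC1CCCCCC1`: > 10000 nM

In an assay on HEK293 cells for inhibition of Monoacylglycerol lipase ABHD6 (Homo sapiens), with stated times of 30 min and 5 min (on this read-out lower numbers stand for stronger inhibition and higher numbers for weaker inhibition), compound 1 gives 3000 nM. Compound 2 gives > 10000 nM, which is a limit of the assay. Compound 3 likewise gives > 10000 nM, a limit of the assay, so compound 3 stands at the weak end of the values shown, where the limit of > 10000 nM in this assay, at which 2 of the 3 values shown sit, holds.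

Compound 4, `O=C(NC1CCCCCC1)c1c(-c2ccccc2)c(-c2ccccc2)cn(Cc2ccc(F)cc2)c1=O`, differs from compound 3 by phenyl in place of methyl on an aromatic carbon. Going by the values given here, the one measured step, an at least 3.3-fold higher number from compound 1 to compound 2 (0.52 log units; beyond the scatter), shows that removing bromo from the core loses potency; a larger group entering at an aromatic carbon might therefore regain some, though compound 3 with methyl already sits at the limit. A gain to a measurable number is expected, an at least 3.3-fold lower number from compound 3 to compound 4 (0.52 log units; beyond the scatter), with wide uncertainty. Compound 4 is expected at 3000 nM, between 500 nM and 15000 nM.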

Compound 4, half-maximal inhibitory concentration: > 10000 nM
Compound 4: a limit, no number; the forecaster's own chance of this, stated with the estimate: 40%; middle value at least 3.3-fold (0.52 log units) away from the limit.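

In this assay, putting phenyl where bromo stood gives an at least 3.3-fold higher number from compound 1 to compound 4 (0.52 log units; beyond the scatter), so phenyl there does not retain what bromo gives. The steps to compound 4 from compound 2 and from compound 3 cannot be read, leaving the change from methyl to phenyl opposite the ring nitrogen without a size. Compound 4 gives a limit of the assay, and only compound 1 carries a number: the limit of > 10000 nM in this assay, at which 3 of the 4 values shown sit.

Open, from the compounds shown here alone, is whether chloro or iodo in place of bromo keeps a measurable number. Also open, going by these compounds, is whether a group other than phenyl opposite the ring nitrogen, such as an amine, changes the read-out.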